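A few compounds are considered here, and "the series" means these few. Any claim that something is new, unique, unknown or untested is made for them only; others in the source may bear on it.

In an assay on cells (Oocyte) for inhibition of pannexin-1 (Mus musculus), read by voltage clamp, tested at 50 uM, in the presence of a further agent that is not named here (on this read-out lower numbers stand for less inhibition and higher numbers for more inhibition at the one concentration tested (going by the name of the read-out)), the measured compounds stand as follows:
Compound 1 `O=C(O)c1cc2cc([N+](=O)[O-])ccc2n1CCCc1ccccc1` gives 65.5%.
Compound 2 `O=C(O)c1cc2cc([N+](=O)[O-])ccc2n1Cc1ccccc1` gives 51.3%.
Compound 3 `O=C(O)c1cc2cc(S(=O)(=O)NCc3ccccc3)ccc2n1Cc1ccccc1` gives 42%.

Compound 1 is the highest of the three numbers; compound 2 is nearest and compound 3 furthest, both beyond the scatter. Compound 4 `O=C(O)c1cc2cc([N+](=O)[O-])ccc2n1CCCCCc1ccccc1` differs from compound 1 by phenethyl in place of phenyl on a saturated chain carbon, three bonds along the chain from an aromatic nitrogen. Within the data shown here, the one measured step that bears on this is a number 14.2 percentage points lower from compound 1 to compound 2 (beyond the scatter), where a shorter chain lowered inhibition modestly. Going the other way, toward a longer chain, a modest rise or no change beyond the scatter is expected. Compound 4 is therefore estimated at 70%, within 55% to 85%, which means an expected step of a number 4.5 percentage points higher from compound 1 to compound 4 (within the scatter).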

Compound 4, a percentage reported as inhibition, at one concentration (the size of the read-out at that concentration, not a potency): 58%
The estimate for compound 4 lay 12 percentage points above the measured number, and the stated range covers the measured number.
By their numbers in this assay, from the lowest: compounds 3, 2, 4 and 1 (each within the scatter of the next, the first and the last beyond it).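

In this assay, putting phenethyl in place of phenyl on this chain gives a number 7.5 percentage points lower from compound 1 to compound 4 (within the scatter) and so leaves the two compounds indistinguishable. The shorter chain instead gives a number 14.2 percentage points lower from compound 1 to compound 2 (beyond the scatter) and is the only one of these two chain steps beyond the scatter, so inhibition at this position withstands lengthening better than shortening, though the longer chain shows no gain. No available measurement explains this difference. As far as these compounds go, what an amine or a hydroxyl group on this chain in place of the phenyl ring would do remains open, as does the effect of a still longer chain.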